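The source may report more compounds than this note shows. Statements on the series, on what has been measured and on what is new or still open speak of the compounds shown alone.

Of the compounds shown here, three built on one shared core have been measured: compound 1 `Cn1cc(C2=C(c3n[nH]c4ncccc34)C(=O)N(c3cccc4ccccc34)C2=O)c2ccccc21`, compound 2 `Cn1cc(C2=C(c3nn(CCCCn4ccnc4)c4ncccc34)C(=O)NC2=O)c2ccccc21` and compound 3 `Cn1cc(C2=C(c3nn(CCCCn4ccnc4)c4ncccc34)C(=O)N(c3ccccc3)C2=O)c2ccccc21`. In a functional assay on ECa-109 cells (Homo sapiens) for antiproliferative activity, read by MTT assay, with a stated time of 48 h (on this read-out lower numbers stand for stronger inhibition and higher numbers for weaker inhibition), compound 1 reaches only the limit of the method, > 100000 nM, so no number is known for it; this is the case described by the limit of > 100000 nM in this assay, at which 1 of the 3 values shown sits. Compound 2 gives 23500 nM in this assay. Compound 3 gives 7540 nM in this assay. Of the two numbers, compound 2 stands highest, and its nearest neighbour is compound 3, the difference being a 3.1-fold lower number from compound 2 to compound 3 (0.49 log units; beyond the scatter), which comes from phenyl in place of hydrogen on an amide-type nitrogen in a ring.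

Compound 4 `Cn1cc(C2=C(c3nn(CCCN4CCCCC4)c4ncccc34)C(=O)NC2=O)c2ccccc21` is not yet measured. It differs from compound 2 by piperidin-1-yl in place of (1H-imidazol-1-yl)methyl on a saturated chain carbon, three bonds along the chain from an aromatic nitrogen. Within the data shown here, the single measured step concerns the amide-type nitrogen in a ring, not the saturated chain, so none of the measured steps bears directly on this change, and no direction can be read from them. The expectation is therefore a step of about a 1.2-fold lower number from compound 2 to compound 4 (0.07 log units; within the scatter), one that stays within the usual scatter. Compound 4 is thus estimated to give about 20000 nM in this assay, with a range from 6000 nM to 65000 nM.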

Compound 4, half-maximal inhibitory concentration: 42300 nM
Beside the measured number, compound 4's estimate is 2.1-fold (0.33 log units) below it; the measured number falls inside the stated range.
By their numbers in this assay, from the lowest: compound 3; then compounds 2 and 4 (each within the scatter of the next). At a limit, above all of these: compound 1.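

In this assay, the saturated chain now has a measured step of its own: exchanging 4-(1H-imidazol-1-yl)butyl for 3-(piperidin-1-yl)propyl gives a 1.8-fold higher number from compound 2 to compound 4 (0.26 log units; within the scatter) for this change. Among these compounds, at this place, on a saturated chain carbon, three bonds along the chain from an aromatic nitrogen, a five-membered aromatic ring and a six-membered non-aromatic ring therefore cannot be told apart on this read-out, whereas the only step beyond the scatter so far remains the one on the amide-type nitrogen, a 3.1-fold lower number from compound 2 to compound 3 (0.49 log units; beyond the scatter) for that change. Nothing measured here offers an explanation for how these two side chains compare.

From the compounds shown here alone, it remains open whether a different group at this place, such as a dimethylamino group, a carboxylic acid or a longer chain, would move the number beyond the scatter. Going by these compounds, it is also open whether phenyl on the amide-type nitrogen would give a similar step with 3-(piperidin-1-yl)propyl in place, and whether a benzyl group there would do the same.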